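Aryl ether swap at the shared core: compound 3 to compound 4

The source may report more compounds than this note shows. Statements on the series, on what has been measured and on what is new or still open speak of the compounds shown alone.

Compound 1 `COc1ccc(Oc2ccc3cc(NC(=O)c4ccc(OC(C)=O)c(CC=C(C)C)c4)c(=O)oc3c2C)cc1`: in a functional assay on SK-BR-3 cells (Homo sapiens) for antiproliferative activity (on this read-out lower numbers stand for stronger inhibition and higher numbers for weaker inhibition), compound 1 gives 19500 nM.
Compound 2 `COc1cccc(Oc2ccc3cc(NC(=O)c4ccc(OC(C)=O)c(CC=C(C)C)c4)c(=O)oc3c2C)c1`: compound 2 gives 13700 nM.
Compound 3 `COc1cccc(Oc2ccc3cc(NC(=O)c4ccc(O)c(CC=C(C)C)c4)c(=O)oc3c2C)c1`: compound 3 gives 33100 nM.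

Compound 3 carries the highest number of the three; the step of a 2.4-fold higher number from compound 2 to compound 3 (0.38 log units; beyond the scatter) lies beyond the scatter, while its gap to compound 1 is within it. Compound 4 `CC(C)=CCc1cc(C(=O)Nc2cc3ccc(Oc4ccc(C(C)(C)C)cc4)c(C)c3oc2=O)ccc1O` differs from compound 3 by 4-(tert-butyl)phenyl in place of 3-methoxyphenyl on an oxygen on an aromatic ring. Among the compounds with values here, the only measured change at that oxygen is a 1.4-fold lower number from compound 1 to compound 2 (0.15 log units; within the scatter), which stayed within the scatter, and no measured step covers the entering group. Compound 4 is therefore expected to show a step of a 1.3-fold lower number from compound 3 to compound 4 (0.12 log units; within the scatter) that stays within the scatter. For compound 4 the estimated value is 25000 nM, with a range from 8000 nM to 80000 nM.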

Compound 4, half-maximal inhibitory concentration: 68300 nM
Compound 4: middle estimate off by 2.7-fold (0.44 log units), on the low side, and the stated range covers the measured number.
By their numbers in this assay, from the lowest: compounds 2, 1 and 3 (each within the scatter of the next, the first and the last beyond it); then compound 4.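

Changing the aryl group on this oxygen can move the number beyond the scatter: 4-(tert-butyl)phenyl in place of 3-methoxyphenyl gives a 2.1-fold higher number from compound 3 to compound 4 (0.31 log units; beyond the scatter), whereas the earlier swap at this oxygen, a 1.4-fold lower number from compound 1 to compound 2 (0.15 log units; within the scatter), stayed within it. The entering group has no hydrogen-bond acceptor, but this single step cannot separate losing the methoxy group from gaining the tert-butyl group. Nothing available explains the step. Still open, as far as these compounds go, is how an amine or a carboxylic acid on this aromatic ring would read. Also open, from the compounds shown here alone, is whether acetyl on the hydroxyl of compound 4 would lower its number.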